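The source may report more compounds than this note shows. Statements on the series, on what has been measured and on what is new or still open speak of the compounds shown alone.

Measured compounds:
compound 1, `CC1=NC(C)=C(C(=O)O)C(c2ccccc2[N+](=O)[O-])/C1=C(\O)OC/C=C/c1ccccc1`: 31 nM
compound 2, `CC1=NC(C)=C(C(=O)O)C(c2ccc([N+](=O)[O-])cc2)/C1=C(\O)OC/C=C/c1ccccc1`: 1600 nM
compound 3, `CC1=NC(C)=C(C(=O)O)C(c2cccc(F)c2)/C1=C(\O)OC/C=C/c1ccccc1`: 20 nM

In a functional assay on thoracic aorta for inhibition of Voltage-gated L-type calcium channel (Rattus norvegicus) (a lower number here means a stronger inhibitor, a higher number a weaker inhibitor), compound 3 gives the lowest of the three numbers. Its gap to compound 1 is small: a 1.6-fold lower number from compound 1 to compound 3 (0.19 log units; within the scatter). Compound 2 stands far apart, an 80-fold lower number from compound 2 to compound 3 (1.90 log units; beyond the scatter). Compound 4, `CC1=NC(C)=C(C(=O)O)C(c2cccc(Cl)c2)/C1=C(\O)OC/C=C/c1ccccc1`, differs from compound 3 in one place: chloro in place of fluoro on an aromatic carbon. For the measured compounds named here, no measured step swaps one halogen for another. Going by the values given here, the only step that touches the 3-fluorophenyl ring, from compound 1 to compound 3, stayed within the scatter, while both large steps involve the 4-nitrophenyl group of compound 2. The expected step is therefore small, a 1.3-fold lower number from compound 3 to compound 4 (0.10 log units; within the scatter). Compound 4 is estimated at 16 nM, with a range from 5 nM to 50 nM.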

Compound 4, half-maximal inhibitory concentration: 20 nM
The estimate for compound 4 lay 1.3-fold (0.10 log units) below the measured number; the range from low to high includes it.
By their numbers in this assay, from the lowest: compounds 3, 4 and 1 (each within the scatter of the next); then compound 2.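

In this assay, exchanging one halogen for the other at this place on the ring leaves the number unchanged (no change at the digits printed from compound 3 to compound 4 (within the scatter)). Compound 4 also stays within the scatter of the 2-nitrophenyl compound (a 1.6-fold lower number from compound 1 to compound 4 (0.19 log units; within the scatter)), while the large gap to the 4-nitrophenyl compound remains (an 80-fold lower number from compound 2 to compound 4 (1.90 log units; beyond the scatter)), so compound 2 alone stands apart among these four. No supporting measurement accounts for these results.

As far as these compounds go, whether a methyl group, a methoxy group or an amine at this same place would match the two halogens remains open.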